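The compounds below may be only part of what the source reports. "The series", "measured", "known", "first", "only" and "open" are said of these compounds alone.

The measured compounds and their values in a functional assay on the whole organism for activation, with Mus musculus as the target; on this read-out lower numbers stand for an effect already at smaller amounts and higher numbers for an effect only at larger amounts of compound:
compound 1 `CCCCc1nc(N)c2nc(O)n(Cc3ccccc3)c2n1` gives 0.3 mg/kg
compound 2 `CCCCCOc1nc(N)c2nc(O)n(Cc3ccccc3)c2n1` gives 0.3 mg/kg
compound 3 `Nc1ncnc2c1nc(O)n2Cc1ccccc1` gives 30 mg/kg

Compound 3 stands at the highest number of the three. Its nearest neighbour is compound 1, separated by the step of a 100-fold higher number from compound 1 to compound 3 (2.00 log units; beyond the scatter); its furthest is compound 2, separated by a 100-fold higher number from compound 2 to compound 3 (2.00 log units; beyond the scatter).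

Compound 4 `CCCc1nc(N)c2nc(O)n(Cc3ccccc3)c2n1` differs from compound 3 by propyl in place of hydrogen on an aromatic carbon. The change places a propyl on the aromatic carbon between two ring nitrogen atoms where compound 3 carries hydrogen. Among the compounds with values here, two measured steps bear on this and run in the opposite direction: a 100-fold higher number from compound 1 to compound 3 (2.00 log units; beyond the scatter) and a 100-fold higher number from compound 2 to compound 3 (2.00 log units; beyond the scatter) both show that taking butyl or pentyloxy off that carbon raises the number greatly, while no change at the digits printed from compound 1 to compound 2 (within the scatter) shows that butyl and pentyloxy give the same number. Propyl is a shorter chain than butyl, and no measured compound shows how chain length matters at that carbon, so the expectation rests on those two steps alone. Compound 4 is therefore expected to show a large fall in number, a 60-fold lower number from compound 3 to compound 4 (1.78 log units; beyond the scatter). The estimate for compound 4 in this assay is 0.5 mg/kg, with a range from 0.15 mg/kg to 2 mg/kg.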

Compound 4, minimum effective dose: 3 mg/kg
Estimate against measurement, compound 4: 6.0-fold (0.78 log units) below, and the stated range ends below it.
By their numbers in this assay, from the lowest: compounds 1 and 2 (each within the scatter of the next); then compound 4; then compound 3.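

In this assay, propyl at the aromatic carbon between two ring nitrogen atoms recovers only part of what the longer groups there give: the gain over hydrogen is (a 10-fold lower number from compound 3 to compound 4 (1.00 log units; beyond the scatter)), yet the shorter chain still falls short of pentyloxy (a 10-fold higher number from compound 2 to compound 4 (1.00 log units; beyond the scatter)) and of butyl (a 10-fold higher number from compound 1 to compound 4 (1.00 log units; beyond the scatter)). Within the data shown here, the earlier compounds showed only that a group at this carbon matters, whereas compound 4 shows that the size of the effect depends on which group is there, and that removing the terminal methyl of butyl matters a great deal. Read along hydrogen, propyl and butyl, the number falls stepwise, but the series does not simply continue with pentyloxy, since compound 2 stays level with compound 1 (no change at the digits printed from compound 1 to compound 2 (within the scatter)) and the oxygen link and extra length cannot be told apart in that pair.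

The compounds shown leave open whether ethyl, methyl or a longer chain such as hexyl would extend this trend, and whether propoxy would match propyl or pentyloxy. Nothing given here accounts for the sharp difference between propyl and butyl.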